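Notes on compound 4: methoxy in place of isopropyl

The source may hold more compounds than are shown below. What is called first, only, known or untested is meant among the compounds shown, and "the series" means these compounds.

Compound 1 `Cc1cc(C(N)=O)nn1Cc1cc(Cl)ccc1OCC(C)C` gives 3.1 in a physicochemical assay for lipophilicity, at pH 7.4; a higher number here means a more lipophilic compound, a lower number a more polar compound.
Compound 2 `Cc1cc(NC(=O)C(C)C)nn1Cc1cc(Cl)ccc1OCc1ccccc1` gives only a limit of the assay, > 3.7.
Compound 3 `Cc1cc(NC(=O)C2CCCCC2)nn1Cc1cc(Cl)ccc1OCC(C)C` likewise gives only a limit, > 3.7.

Compound 2 thus stands at the limit of > 3.7 in this assay, at which 2 of the 3 values shown sit, and no number is known for it. Among the compounds with values here, the single measured step, a number at least 0.60 log units higher from compound 1 to compound 3 (beyond the scatter), concerns a different part of the molecule and does not touch the carbonyl carbon in question. The unmeasured compound 4 `COC(=O)Nc1cc(C)n(Cc2cc(Cl)ccc2OCc2ccccc2)n1` differs from compound 2 by methoxy in place of isopropyl on a carbonyl carbon. Within the data shown here, no measured step bears on this exchange, so the expectation rests on the change alone. The step is expected to be a fall, a number at least 0.30 log units lower from compound 2 to compound 4 (that floor lies within the scatter), though a value at the limit again cannot be excluded. Compound 4 is estimated at 3.4, with a range from 2.9 to 3.9.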

Compound 4, distribution coefficient: > 3.7
Compound 4 ended at the assay's limit (the forecaster's own chance of this, stated with the estimate: 30%); middle value at least 0.30 log units away from the limit.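

Compound 2 and compound 4 both stand at a limit rather than a number, so no step can be read between them: the limit of > 3.7 in this assay, at which 3 of the 4 values shown sit.

The compounds shown leave open what methoxy in place of isopropyl on a carbonyl carbon does to the distribution coefficient.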